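The compounds below may be only part of what the source reports. "The series", "measured", "known", "first", "only" and "open" are said of these compounds alone.

Compound 1, whose structure is `CNCc1c(OC)cc(Oc2cccc(Nc3ccccc3)c2)cc1OC`, is tested in a functional assay on DLD-1 cells (Homo sapiens) for inhibition, read by MTT assay, with a stated time of 72 h (on this read-out higher numbers stand for weaker inhibition and lower numbers for stronger inhibition), where it gives 11900 nM. Two close relatives frame it. Compound 2, `COc1cc(Oc2cccc(Nc3ccccc3)c2)cc(OC)c1CNC(C)C`, returns only a limit of the assay in this assay, > 20000 nM. That step, an at least 1.6-fold higher number from compound 1 to compound 2 (0.22 log units; that floor lies within the scatter), comes from the change isopropyl in place of methyl on an amine nitrogen, and it ends at a limit, (the limit of > 20000 nM in this assay, at which 1 of the 3 values shown sits). Compound 3, `COc1ccc([C@@H](C)NCc2c(OC)cc(Oc3cccc(Nc4ccccc4)c3)c(OC)c2OC)cc1`, gives 3500 nM, a lower number than compound 1, and that gap lies beyond the scatter; compound 1 therefore holds the highest of the two numbers shown. Compound 2 stands apart from this comparison, since its result is only a limit of the assay.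

Compound 4, `COc1ccc(CCCNCc2c(OC)cc(Oc3cccc(Nc4ccccc4)c3)cc2OC)cc1`, differs from compound 1 by 2-(4-methoxyphenyl)ethyl in place of hydrogen on a saturated chain carbon bound to an amine nitrogen. Within the data shown here, no measured step covers this exact change. The step to compound 2 shows that a small added branch on the amine nitrogen pushes the number to a limit, while compound 3, carrying a larger aryl-bearing group on that nitrogen, gives the lowest number shown. Weighing both, the expected outcome is a modest move to a lower number, a 2.4-fold lower number from compound 1 to compound 4 (0.38 log units; beyond the scatter), and compound 4 is estimated at 5000 nM, between 1500 nM and 15000 nM.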

Compound 4, half-maximal inhibitory concentration: 2540 nM
Estimate against measurement, compound 4: 2.0-fold (0.29 log units) above, and the stated range covers the measured number.
By their numbers in this assay, from the lowest: compounds 4 and 3 (each within the scatter of the next); then compound 1. At a limit, above all of these: compound 2.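

Enlarging the group on the amine nitrogen need not weaken the result: in this assay, adding 2-(4-methoxyphenyl)ethyl on the saturated chain carbon bound to that nitrogen gives a 4.7-fold lower number from compound 1 to compound 4 (0.67 log units; beyond the scatter). Measured against the isopropyl group, 3-(4-methoxyphenyl)propyl gives an at least 7.8-fold lower number from compound 2 to compound 4 (0.89 log units; beyond the scatter). That step is only a floor, because compound 2 sits at a limit of the assay: the limit of > 20000 nM in this assay, at which 1 of the 4 values shown sits.

The compounds shown do not separate the contribution of the chain from that of the aromatic ring or its methoxy group. A 3-phenylpropyl group without the methoxy group, a shorter or longer chain carrying the same ring, or a carboxylic acid in place of the methoxy group would each help to tell these contributions apart.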